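Fluoro in place of nitro: compound 3 to compound 4

A few compounds are considered here, and "the series" means these few. Any claim that something is new, unique, unknown or untested is made for them only; others in the source may bear on it.

Compound 1 (`C/C(=N\NC(=S)Nc1ccccc1I)c1ccccn1`): 8.09 nM
Compound 2 (`C/C(=N\NC(=S)Nc1ccc(I)cc1)c1ccccn1`): 64 nM
Compound 3 (`CC(=NNC(=S)Nc1cccc([N+](=O)[O-])c1)c1ccccn1`): 140 nM

In a functional assay on T98G cells (Homo sapiens) for cytotoxicity, read by MTT assay, with a stated time of 48 h (on this read-out higher numbers stand for weaker inhibition and lower numbers for stronger inhibition), compound 3 stands highest of the three and is thus the weakest inhibitor, above both compound 2 and compound 1. Compound 4 (`CC(=NNC(=S)Nc1cccc(F)c1)c1ccccn1`) is unmeasured and carries fluoro in place of nitro on an aromatic carbon. Within the data shown here, no measured pair shows this change alone. Among the measured compounds shown here, compound 3 is the only nitro compound measured, and the two without nitro both give lower numbers. A moderate move towards stronger inhibition is therefore expected, estimated as a 2.3-fold lower number from compound 3 to compound 4 (0.37 log units; beyond the scatter) in all. The estimate for compound 4 is 60 nM (expected range 15 nM to 240 nM).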

Compound 4, half-maximal inhibitory concentration: 12 nM
Beside the measured number, compound 4's estimate is 5.0-fold (0.70 log units) above it; the whole stated range lies above it.
By their numbers in this assay, from the lowest: compounds 1 and 4 (each within the scatter of the next); then compound 2; then compound 3.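

In this assay, replacing nitro with fluoro on this aromatic carbon, meta to a large group, gives a 12-fold lower number from compound 3 to compound 4 (1.07 log units; beyond the scatter), a large step and the first measured for a single change here. It shows that the number at this position depends strongly on the group it carries, with fluoro far better than nitro. No measurement at hand accounts for the step. Still open, on these data alone, is whether an amine, a methoxy group or plain hydrogen at this place would stand nearer compound 4 or compound 3.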